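The source may hold more compounds than are shown below. What is called first, only, known or untested is meant among the compounds shown, and "the series" means these compounds.

Compound 1 `Cc1ccc(C(=O)OC2CCC(CN3CCN(c4cc(=O)c5cc(C(F)(F)F)cc([N+](=O)[O-])c5s4)CC3)CC2)cc1` gives 9.7% in an ADME assay on cells (Hepatocyte, Homo sapiens) for metabolic stability, with a stated time of 30 min (on this read-out lower numbers stand for a less stable compound and higher numbers for a more stable compound), and among the three compounds with numbers its value sits at the top, though neither gap is beyond the scatter: compound 3 `O=C(OC1CCC(CN2CCN(c3cc(=O)c4cc(C(F)(F)F)cc([N+](=O)[O-])c4s3)CC2)CC1)C1CCCCC1` gives 2.8% and compound 2 `Nc1cc(C(F)(F)F)cc2c(=O)cc(N3CCN(CC4CCCCC4)CC3)sc12` gives 0.9%. For the measured compounds named here, the one step between neighbouring measured compounds, a number 6.9 percentage points lower from compound 1 to compound 3 (within the scatter), exchanged cyclohexyl for 4-methylphenyl on a carbonyl carbon and stayed within the scatter. Compound 4 `COc1ccc(C(=O)OC2CCC(CN3CCN(c4cc(=O)c5cc(C(F)(F)F)cc([N+](=O)[O-])c5s4)CC3)CC2)cc1` differs from compound 1 by methoxy in place of methyl on an aromatic carbon. Going by the values given here, no measured step touches this position, so the sole step gives only a hint that the ester end tolerates variation without a change beyond the scatter. In this assay compound 4 is therefore expected at 9%, within 2% to 22%. The expected step is a number 0.7 percentage points lower from compound 1 to compound 4 (within the scatter).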

Compound 4, percent of the compound remaining: 12.2%
Compound 4: the middle estimate sits 3.2 percentage points below what was measured; the measured number falls inside the stated range.
By their numbers in this assay, from the lowest: compounds 2, 3, 1 and 4 (each within the scatter of the next, the first and the last beyond it).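

In this assay, for the compounds shown here, methoxy in place of methyl on the aromatic carbon gave a number 2.5 percentage points higher from compound 1 to compound 4 (within the scatter), the first measured change at this position, and so the added oxygen left the read-out within the scatter. The exchange of cyclohexyl for 4-methoxyphenyl on the carbonyl carbon gave a number 9.4 percentage points higher from compound 3 to compound 4 (within the scatter), so these two esters are not told apart either. Nothing available accounts for these numbers. The compounds shown leave open whether an amine or a carboxylic acid on this aromatic carbon would give a step beyond the scatter. They also leave open what an amide in place of the ester would do.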